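Removing the Methoxybenzyl Group from Compound 2

This account rests on a few compounds, and the source may have more. Where it says the series, first, only, none or still open, it means among the compounds named here.

Compound 2 `CCCCCc1c(Br)c(=O)c2cc([N+](=O)[O-])ccc2n1Cc1ccc(OC)cc1` gives the highest number of the three measured in an assay on isolated protein for inhibition of Intestinal-type alkaline phosphatase (Bos taurus), read by spectrophotometry, with stated times of 7 min and 15 min (on this read-out higher numbers stand for weaker inhibition and lower numbers for stronger inhibition), at 122000 nM. Compound 1 `CCCCCc1cc(=O)c2cc([N+](=O)[O-])ccc2n1Cc1ccc(OC)cc1` sits lowest with 1380 nM, and compound 3 `CCc1ccc(-c2c(-c3ccc(C)cc3)n(Cc3ccc(OC)cc3)c3ccc([N+](=O)[O-])cc3c2=O)cc1` lies between them with 5750 nM. Among the measured compounds shown here, the only single-point step among them, an 88-fold higher number from compound 1 to compound 2 (1.95 log units; beyond the scatter), shows how strongly adding the bromo group raised the number. Compound 4 `CCCCCc1[nH]c2ccc([N+](=O)[O-])cc2c(=O)c1Br` differs from compound 2 in a different place: hydrogen in place of 4-methoxybenzyl on an aromatic nitrogen. For the measured compounds named here, no measured pair shows this particular change, and the bromo step offers no guide to its direction or size. The expectation is therefore no step beyond the scatter, held with wide uncertainty. Compound 4 is expected to give 100000 nM in this assay, with a range from 20000 nM to 500000 nM, which means an estimated 1.2-fold lower number from compound 2 to compound 4 (0.09 log units; within the scatter).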

Compound 4, half-maximal inhibitory concentration: 3060 nM
The estimate for compound 4 lay 33-fold (1.51 log units) above the measured number, outside the stated range (below it).
By their numbers in this assay, from the lowest: compound 1; then compounds 4 and 3 (each within the scatter of the next); then compound 2.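

In this assay, hydrogen in place of 4-methoxybenzyl on the aromatic nitrogen gives a 40-fold lower number from compound 2 to compound 4 (1.60 log units; beyond the scatter) and thus stronger inhibition. Among the compounds shown here, all the earlier compounds carried 4-methoxybenzyl at this position, leaving its loss untested; with the bromo group present, inhibition clearly does not depend on keeping it. No evidence here explains why the number falls. Still open, as far as these compounds go, is whether a methyl group or a longer chain on this nitrogen would behave like hydrogen or like 4-methoxybenzyl, and whether the same change would lower the number without the bromo group.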